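The source may report more compounds than this note shows. Statements on the series, on what has been measured and on what is new or still open speak of the compounds shown alone.

Three members of the series carry a result in a functional assay on HL-60 cells (Homo sapiens) for antiproliferative activity, read by MTT assay; a lower number here means a stronger inhibitor, a higher number a weaker inhibitor. Compound 1 `CCC[C@@H]1O[C@H](COCc2ccccc2)[C@@H](OCc2ccccc2)[C@H](OCc2ccccc2)[C@@H]1O` gives "not active" (no number reported) in this assay, and compound 2 `CCC[C@H]1O[C@H](COCc2ccccc2)[C@H](OCc2ccccc2)[C@H](OCc2ccccc2)[C@H]1O` likewise gives "not active" (no number reported); for this pair the data record (the fact that compounds 1 and 2 differ only in the configuration as drawn). For the measured compounds named here, compound 3 `O[C@@H]1[C@@H](OCc2ccccc2)[C@H](OCc2ccccc2)[C@@H](COCc2ccccc2)O[C@H]1CC1CCCCC1` gives 4100 nM in this assay, the only number in the set, so it is the sole reference point for any expectation, and no step between measured compounds that differ in one place is available.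

Compound 4 `CCC[C@@H]1O[C@H](COCc2ccccc2)[C@@H](OCc2ccccc2)[C@H](OCc2ccccc2)[C@H]1O` has not been measured. Against compound 3 the change is ethyl in place of cyclohexyl on a saturated chain carbon bound to a saturated ring carbon. The two compounds that carry propyl in place of cyclohexylmethyl, compound 1 with "not active" (no number reported) and compound 2 with "not active" (no number reported), both fall short of a measurable number in this assay. A step toward weaker inhibition, well beyond the scatter, is therefore expected a 6.1-fold higher number from compound 3 to compound 4 (0.79 log units; beyond the scatter), and a result reported only as a limit is a real possibility. Compound 4 is expected to give about 25000 nM in this assay, with a range from 7000 nM to 90000 nM.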

Compound 4, half-maximal inhibitory concentration: 11700 nM
For compound 4 the middle estimate is 2.1-fold (0.33 log units) above the measured one, and the stated range covers the measured number.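

In this assay, ethyl in place of cyclohexyl on a saturated chain carbon bound to a saturated ring carbon gives a 2.9-fold higher number from compound 3 to compound 4 (0.46 log units; beyond the scatter), a modest step, so a measurable number does not depend on the cyclohexyl ring. The propyl group alone therefore does not set the outcome, since compound 4 carries it and gives a number, whereas compound 1 gives "not active" (no number reported): the fact that compounds 1 and 4 differ only in the configuration as drawn The same contrast holds for compound 2, which gives "not active" (no number reported): the fact that compounds 2 and 4 differ only in the configuration as drawn

As far as these compounds go, how a longer chain such as hexyl, or an amine in place of cyclohexyl, would read here stays open. Whether cyclohexylmethyl shows the same dependence on configuration also stays open, as compound 3 is the only compound shown with that group.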